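The source may report more compounds than this note shows. Statements on the series, on what has been measured and on what is new or still open speak of the compounds shown alone.

Compound 2 `Cc1cc(-c2sc(Cc3cccc(N(C)C)c3)nc2C)ccc1C(N)=O` holds the higher of the two results known so far: in a functional assay on cells for agonist activity at G-protein coupled receptor 52 (Homo sapiens), read by AlphaScreen and cAMP accumulation, with a stated time of 30 min (on this read-out lower numbers stand for smaller maximal responses and higher numbers for larger maximal responses), compound 2 reaches 101%. Going by the values given here, compound 1 `Cc1cc(-c2sc(Cc3cccc(C(F)(F)F)c3)nc2C)ccc1C(N)=O` differs from it at a single aromatic carbon and gives 86% in this assay, so the only step known at that position is a number 15 percentage points higher from compound 1 to compound 2 (beyond the scatter). Compound 3 `Cc1cc(-c2sc(Cc3cccc(F)c3)nc2C)ccc1C(N)=O` alters the same place again: fluoro in place of dimethylamino on an aromatic carbon. Among the compounds with values here, that one step is the sole guide, and fluoro has not been seen here before. For compound 3 a modest drop is expected, a step of a number 11 percentage points lower from compound 2 to compound 3 (beyond the scatter). The response of compound 3 is therefore estimated at 90%, within 75% to 105%.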

Compound 3, largest response reached (Emax), in percent of the reference or control that the assay uses: 75%
Compound 3: the middle estimate sits 15 percentage points above what was measured; measured number inside the range.
By their numbers in this assay, from the lowest: compound 3; then compound 1; then compound 2.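

In this assay fluoro at this aromatic carbon falls below both earlier groups, dimethylamino (a number 26 percentage points lower from compound 2 to compound 3 (beyond the scatter)) and trifluoromethyl (a number 11 percentage points lower from compound 1 to compound 3 (beyond the scatter)). The three compounds now sit at three separate levels, so the maximal response clearly depends on which group occupies this carbon. No measurement here explains why these groups differ. Still open, as far as these compounds go, is how a primary amine, a methoxy group or a carboxylic acid would behave at this carbon. Plain hydrogen there would also show whether fluoro lowers the response or dimethylamino raises it.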